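Adding a Decyl Chain onto the Piperidine Core

A few compounds are considered here, and "the series" means these few. Any claim that something is new, unique, unknown or untested is made for them only; others in the source may bear on it.

Measured so far in a functional assay on DU-145 cells (Homo sapiens) for inhibition, read by MTT assay, with stated times of 18 h and 4 h; a higher number here means a weaker inhibitor, a lower number a stronger inhibitor:
compound 1 `CCCCCCCCCCCCCCCCOP(=O)(O)OCCSC(=S)N1CCCCCC1`: 17600 nM
compound 2 `CCCCCCOP(=O)(O)OCCSC(=S)N1CCCCCC1`: 77400 nM
compound 3 `CCCCCCOP(=O)(O)OCCSC(=S)N1CCCCC1`: > 100000 nM, which is a limit of the assay and not a number.

Compound 2 and compound 1 differ in one place, (decyl in place of hydrogen on a saturated chain carbon, six bonds along the chain from an oxygen on an unsaturated carbon), and this change made the step of a 4.4-fold lower number from compound 2 to compound 1 (0.64 log units; beyond the scatter). The two cores differ by piperidin-1-yl in place of azepan-1-yl on a thiocarbonyl carbon, and the step of an at least 1.2-fold higher number from compound 2 to compound 3 (0.11 log units; that floor lies within the scatter) shows only a floor, since compound 3 reached the assay limit (the limit of > 100000 nM in this assay, at which 1 of the 3 values shown sits).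

Compound 4 `CCCCCCCCCCCCCCCCOP(=O)(O)OCCSC(=S)N1CCCCC1` is not yet measured. It differs from compound 3 by decyl in place of hydrogen on a saturated chain carbon, six bonds along the chain from an oxygen on an unsaturated carbon, the same change that took compound 2 to compound 1, at the same place. Among the compounds with values here, the step from compound 3 to compound 4 is therefore expected to be of a similar size, an at least 2.5-fold lower number from compound 3 to compound 4 (0.39 log units; beyond the scatter), resting on the one measured pair, compound 2 to compound 1 with its step of a 4.4-fold lower number from compound 2 to compound 1 (0.64 log units; beyond the scatter), although compound 3 offers only a limit as a starting point. For compound 4 the estimate is 40000 nM, with a range from 15000 nM to 100000 nM.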

Compound 4, half-maximal inhibitory concentration: 14700 nM
Compound 4: middle estimate off by 2.7-fold (0.43 log units), on the high side, and the stated range ends above it.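

In this assay, the decyl chain again brought a lower number on the second core, an at least 6.8-fold lower number from compound 3 to compound 4 (0.83 log units; beyond the scatter), which shows that the direction of the change carried over: the same change on two cores in this assay, a 4.4-fold lower number (0.64 log units; beyond the scatter) from compound 2 to compound 1 and an at least 6.8-fold lower number (0.83 log units; beyond the scatter) from compound 3 to compound 4; the limit leaves it open whether they differ. Compound 3 stands at > 100000 nM, which is a limit of the assay and not a number, and the step from it gives only a floor, not the true size of the change on that core. With the decyl chain in place, the swap of one core for the other makes no clear difference, a 1.2-fold lower number from compound 1 to compound 4 (0.08 log units; within the scatter), but two cores are too few to call either result a rule for the series: the same change on two cores in this assay, an at least 1.2-fold higher number (0.11 log units; that floor lies within the scatter) from compound 2 to compound 3 and a 1.2-fold lower number (0.08 log units; within the scatter) from compound 1 to compound 4; the limit leaves it open whether they differ.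

The compounds shown leave open whether a longer chain would lower the number further or whether the gain would level off. They also leave open how an amine or a carboxylic acid at the far end of the chain would compare with the plain decyl chain.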